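The source may report more compounds than this note shows. Statements on the series, on what has been measured and on what is new or still open speak of the compounds shown alone.

Compound 1 `COc1cc(OC)c(OC)cc1/C=C/C(=O)c1ccc(OC)c2c1OC(C)(C)C=C2`, compound 2 `COc1ccc(C(=O)/C=C/c2cccc(F)c2)c2c1C=CC(C)(C)O2` and compound 3 `COc1ccc(C(=O)/C=C/c2ccc(OC)c(OC)c2OC)c2c1C=CC(C)(C)O2` share one core and were each tested in a functional assay on HCT-116 cells (Homo sapiens) for antiproliferative activity, read by MTT assay, with a stated time of 24 h; a higher number here means a weaker inhibitor, a lower number a stronger inhibitor. Compound 1 returns no number there, only a limit of the assay, > 10000 nM. Compound 3 likewise gives only a limit, > 10000 nM. Compound 2 also stops at a limit, > 10000 nM. Compound 2 therefore stands exactly where every measured value sits: the limit of > 10000 nM in this assay, at which 3 of the 3 values shown sit. Going by the values given here, because all values are limits, no step between measured compounds can be drawn, and no ordering among compound 1, compound 2 and compound 3 can be claimed.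

Compound 4 `COc1ccc(C(=O)/C=C/c2ccc(Cl)c(Cl)c2)c2c1C=CC(C)(C)O2` has not yet been measured in this assay. It differs from compound 2 in one place: 3,4-dichlorophenyl in place of 3-fluorophenyl on a double-bonded chain carbon bound to a double-bonded chain carbon. Among the compounds with values here, nothing among the measured values shows what such a change does in this assay. The step that the limit leaves unreadable from compound 2 to compound 4 is the one expected, which is to say none beyond the scatter. Compound 4 is expected to give about 15000 nM in this assay, within 5000 nM to 50000 nM, and it is expected that the assay may again report only a limit rather than a number.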

Compound 4, half-maximal inhibitory concentration: 9440 nM
Beside the measured number, compound 4's estimate is 1.6-fold (0.20 log units) above it; low and high end bracket the measured number.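

In this assay, going by these compounds alone, compound 4 gives 9440 nM, the first true number in this set, so 3,4-dichlorophenyl on a double-bonded chain carbon bound to a double-bonded chain carbon yields a reading within the range of the assay. The change from 3-fluorophenyl reads only as an at least 1.0-fold lower number from compound 2 to compound 4 (0.02 log units; that floor lies within the scatter); the true step could be larger, but nothing here requires that. The other compounds remain at a limit of the assay, and no further step can be read: the limit of > 10000 nM in this assay, at which 3 of the 4 values shown sit.

From the compounds shown here alone, it stays open whether a phenyl ring carrying a single chlorine, a trifluoromethyl group or a nitrile at this place would also return a number. Equally open, going by these compounds, is whether an amine or a carboxylic acid on that ring would give a number at all.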